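The source may report more compounds than this note shows. Statements on the series, on what has been measured and on what is new or still open speak of the compounds shown alone.

Measured compounds:
Compound 1, `COc1ccc(NC(=O)c2cccc(/C=C3\CC(=O)N(c4ccccc4)C3=O)c2)cc1`, gives > 100000 nM in an ADME assay on SW480 cells (Homo sapiens) for cytotoxicity, read by MTT assay, with a stated time of 72 h (on this read-out lower numbers stand for stronger inhibition and higher numbers for weaker inhibition), a limit of the assay.
Compound 2, `COc1ccc(NC(=O)c2cccc(/C=C3\CC(=O)N(c4ccc(C)cc4)C3=O)c2)cc1`, gives 93000 nM.
Compound 3, `CCCCCN1C(=O)C/C(=C\c2cccc(C(=O)NCCCC)c2)C1=O`, gives > 100000 nM, again a limit.

Compound 3 thus stands at the limit, where two of the three values sit (the limit of > 100000 nM in this assay, at which 2 of the 3 values shown sit). Compound 4, `CCCCCN1C(=O)C/C(=C\c2cccc(C(=O)Nc3ccc(OC)cc3)c2)C1=O`, differs from compound 3 by 4-methoxyphenyl in place of butyl on an amide-type nitrogen. For the measured compounds named here, the only measured step, an at least 1.0-fold lower number from compound 1 to compound 2 (0.03 log units; that floor lies within the scatter), concerns a methyl on an aromatic carbon at the far end and lies within the scatter; no measured step covers an exchange on the amide nitrogen. Compound 1, which carries the same 4-methoxyphenyl amide, sits at the limit. Compound 2, carrying it too, gives a number close to that limit. Compound 4 is therefore expected near the limit, estimated at 100000 nM with a range from 50000 nM to 300000 nM. The expected step is a number no higher from compound 3 to compound 4 (the limit leaves the size open), none beyond the scatter.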

Compound 4, half-maximal inhibitory concentration: > 100000 nM
Compound 4 ended at the assay's limit; the forecaster's own chance of this, stated with the estimate: 70%; the middle value sits exactly at the limit.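

In this assay compound 4 gives > 100000 nM as a limit of the assay. On this amide-type nitrogen, butyl and 4-methoxyphenyl both leave the pentyl compounds at the same limit, so this exchange yields no readable gain at this position: the limit of > 100000 nM in this assay, at which 3 of the 4 values shown sit. The step of an at least 1.0-fold higher number from compound 2 to compound 4 (0.03 log units; that floor lies within the scatter) is the only one that can be read, and the steps from compound 3 and from compound 1 to compound 4 cannot.

On these data alone, whether an aminoalkyl chain or a carboxylic acid on this nitrogen would give a number clear of the limit stays open.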